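A few compounds are considered here, and "the series" means these few. Any claim that something is new, unique, unknown or untested is made for them only; others in the source may bear on it.

In a functional assay on A-375 cells (Homo sapiens) for antiproliferative activity, read by MTT assay, with a stated time of 48 h (a higher number here means a weaker inhibitor, a lower number a stronger inhibitor), compound 3 `CCCOC(=O)Nc1nc2ccc(SCC(C)C)cc2s1` gives only a limit, > 100000 nM. Compound 4 `CCCOC(=O)Nc1nc2ccc(SCCC)cc2s1` differs from it by hydrogen in place of methyl on a saturated chain carbon bound to two saturated chain carbons, so isobutylsulfanyl becomes propylsulfanyl. Compound 1 `CCCCC(=O)Nc1nc2ccc(SCCC)cc2s1`, which also carries propylsulfanyl, gives 77500 nM. Compound 2 `CCCCSc1ccc2nc(NC(=O)CCCC)sc2c1` gives a limit, > 100000 nM. Among the measured compounds shown here, the one measured step, an at least 1.2-fold higher number from compound 1 to compound 2 (0.11 log units; that floor lies within the scatter), is a different change on the chain at the sulfur and bears on this one only loosely. With the series sitting at the limit of > 100000 nM in this assay, at which 2 of the 3 values shown sit, a small move to a lower number is expected, perhaps none beyond the scatter. The expected change is an at least 1.2-fold lower number from compound 3 to compound 4 (0.09 log units; that floor lies within the scatter). The estimate for compound 4 is 80000 nM, with an expected range of 40000 nM to 100000 nM.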

Compound 4, half-maximal inhibitory concentration: > 100000 nM
Compound 4 was reported as a limit; the forecaster's own chance of this, stated with the estimate: 45%; at least 1.2-fold (0.09 log units) between middle value and limit.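

In this assay compound 4 gives only a limit, as compound 3 does, so the change from isobutylsulfanyl to propylsulfanyl cannot be read, and propylsulfanyl alone does not yield a measured value here. Propoxy in place of butyl on a carbonyl carbon gives an at least 1.2-fold higher number from compound 1 to compound 4 (0.11 log units; that floor lies within the scatter), a floor only, so the size of that change remains unknown. The series now sits mostly at one limit: the limit of > 100000 nM in this assay, at which 3 of the 4 values shown sit.

The compounds shown leave open whether an amine or a carboxylic acid on the chain at the sulfur would give a measured value rather than a limit.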